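Fluorines for the aniline nitrogen on a chalcone-type arm

A few compounds are considered here, and "the series" means these few. Any claim that something is new, unique, unknown or untested is made for them only; others in the source may bear on it.

The two measured compounds share a core and differ at the aryl group on the carbonyl carbon. In a functional assay on 786-0 cells (Homo sapiens) for cytotoxicity, read by sulforhodamine B assay, with a stated time of 48 h, tested at 0.01 uM (on this read-out lower numbers stand for a stronger effect and higher numbers for a weaker effect at the one concentration tested), compound 1 `COc1cc(-c2cc(/C=C/C(=O)c3ccc(N)cc3)[nH]n2)cc(OC)c1OC` gives 92%, and in this assay compound 2 `COc1ccc(-c2cc(/C=C/C(=O)c3cc(OC)c(OC)c(OC)c3)[nH]n2)cc1OC` gives 100%; the two numbers lie within the scatter of each other, so compound 1 stands level with compound 2 rather than apart from it. Compound 3 `COc1cc(-c2cc(/C=C/C(=O)c3ccc(F)c(F)c3)[nH]n2)cc(OC)c1OC` carries 3,4-difluorophenyl in place of 4-aminophenyl on a carbonyl carbon. Going by the values given here, with no measured step to lean on and both known values near the top of the scale, the step from a number 3 percentage points higher from compound 1 to compound 3 (within the scatter) is expected to stay within the scatter. Compound 3 is therefore estimated at 95%, between 80% and 105%.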

Compound 3, a percentage reported as activity, at one concentration (the size of the read-out at that concentration, not a potency): 95%
Beside the measured number, compound 3's estimate shows no gap at the digits printed; the measured number falls inside the stated range.
By their numbers in this assay, from the lowest: compounds 1, 3 and 2 (each within the scatter of the next).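

In this assay, going by these compounds alone, 3,4-difluorophenyl in place of 4-aminophenyl on the carbonyl carbon gives a number 3 percentage points higher from compound 1 to compound 3 (within the scatter) and is the first single-place step at this position. At this one concentration, the read-out therefore does not separate an aryl group with 0 hydrogen-bond donors and 0 hydrogen-bond acceptors from one with 1 of each. No evidence on hand bears on this result. On these data alone, whether a carboxylic acid or a morpholine on that aryl group would shift the number remains open. So does whether compound 1 and compound 3 would separate at a higher concentration.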